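A Methyl Added to the Amide of Compound 1

A few compounds are considered here, and "the series" means these few. Any claim that something is new, unique, unknown or untested is made for them only; others in the source may bear on it.

Among the measured compounds shown here, compound 1 `CC(=O)N1CCC(c2ccc(-c3cc(C(=O)O)cc4cc(-c5ccc(C(F)(F)F)cc5)ccc34)cc2)CC1` stands at the top of the three numbers so far in a functional assay on the whole organism (strain ICR) for inhibition, with Mus musculus as the target, with stated times of 7 days and 2 h, at a dose of 10 umol/kg by the intraperitoneal route (a lower number here means less inhibition, a higher number more inhibition at the dose given (going by the name of the read-out)), where compound 1 gives 100%. The other two are lower, and both gaps are beyond the scatter: compound 3 `NCCCNC(=O)c1ccc(-c2cc(C(=O)O)cc(-n3cc(-c4ccc(C(F)(F)F)cc4)nn3)c2)s1` gives 74% in this assay, and compound 2 `O=C(O)c1cc(O)c2ccc(-c3ccc(C(F)(F)F)cc3)cc2c1` gives 59.8% in this assay. No pair among these three differs in a single place, so no step between measured compounds can be read off, and the gaps from compound 1 to compound 3 and to compound 2 are simply what the two values show.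

Compound 4 `CCC(=O)N1CCC(c2ccc(-c3cc(C(=O)O)cc4cc(-c5ccc(C(F)(F)F)cc5)ccc34)cc2)CC1` is the next to be measured. It differs from compound 1 in one place: methyl in place of hydrogen on a saturated chain carbon bound to a carbonyl carbon. The read-out of compound 1 already sits at the top of the scale, so a step from compound 1 to compound 4 in this assay can only go downward or stay within the scatter. A change of this size, on the saturated chain carbon bound to a carbonyl carbon, is expected to leave the number close to where it is. Compound 4 is therefore expected to give 95%, within 80% to 100%. The step that this estimate means, a number 5 percentage points lower from compound 1 to compound 4 (within the scatter), is expected to be none beyond the scatter.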

Compound 4, a percentage reported as inhibition, in the whole organism at one dose (the size of the read-out at that dose, not a potency): 71.6%
The estimate for compound 4 lay 23.4 percentage points above the measured number, and the stated range ends above it.
By their numbers in this assay, from the lowest: compound 2; then compounds 4 and 3 (each within the scatter of the next); then compound 1.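

In this assay, the change from 1-acetylpiperidin-4-yl to 1-propanoylpiperidin-4-yl gives a number 28.4 percentage points lower from compound 1 to compound 4 (beyond the scatter) and so moves the number beyond the scatter. This is the only step among the compounds shown that can be read at a single place, and it shows that this position responds to the addition of just one carbon: methyl in place of hydrogen on a saturated chain carbon bound to a carbonyl carbon is enough, with the rest of the core of compound 1 unchanged. No measurement shown here bears on what lies behind this step.

With one step at this position, the compounds shown do not tell whether a longer chain, such as butanoyl in place of propanoyl, would lower the number further or whether the step stops at a single added methyl. They also leave open whether an amine or a hydroxyl on this same saturated chain carbon would keep the number of compound 1 or lower it as the methyl does.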